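Cyclopentyl in place of 2,4-difluorophenyl on the amide

This account rests on a few compounds, and the source may have more. Where it says the series, first, only, none or still open, it means among the compounds named here.

In an in vitro ADME assay on microsomes from liver (Mus musculus) for pharmacokinetics, read by LC-MS, with a stated time of 10 min, tested at 1 uM (on this read-out higher numbers stand for fast clearance and lower numbers for slow clearance), compound 1 `CN1C[C@H](C(=O)Nc2ccccc2)[C@@H](c2ccc(/C=C/C(=O)Nc3ccccc3N)cc2)C1` gives 67 mL/min/kg and compound 2 `CN1C[C@H](C(=O)Nc2ccc(F)c(F)c2)[C@@H](c2ccc(/C=C/C(=O)Nc3ccccc3N)cc2)C1` gives 46 mL/min/kg while compound 3 `CN1C[C@H](C(=O)Nc2ccc(F)cc2F)[C@@H](c2ccc(/C=C/C(=O)Nc3ccccc3N)cc2)C1` gives 27 mL/min/kg on the same core. Compound 3 stands clear of compound 1 only. For the measured compounds named here, the series shows a 2.5-fold lower number from compound 1 to compound 3 (0.39 log units; beyond the scatter) as its one modest step. Both a 1.5-fold lower number from compound 1 to compound 2 (0.16 log units; within the scatter) and a 1.7-fold lower number from compound 2 to compound 3 (0.23 log units; within the scatter) stay inside the noise.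

Compound 4 `CN1C[C@H](C(=O)NC2CCCC2)[C@@H](c2ccc(/C=C/C(=O)Nc3ccccc3N)cc2)C1` carries cyclopentyl in place of 2,4-difluorophenyl on an amide-type nitrogen with the core unchanged. Every measured compound has phenyl or a difluorophenyl on that nitrogen, and none has a non-aromatic ring there, so the measured steps are only indirect guides. Going by the values given here, compound 1 is the one measured compound that, like compound 4, has no fluorine on this group, and compound 1 stands at 67 mL/min/kg. On that basis, the step of a 2.5-fold lower number from compound 1 to compound 3 (0.39 log units; beyond the scatter) is taken as the size guide, read in reverse, and a step of similar size upward is expected in this assay with wide uncertainty. The expected change is a 2.2-fold higher number from compound 3 to compound 4 (0.35 log units; beyond the scatter) according to this estimate. Compound 4 is estimated at 60 mL/min/kg with an expected range from 28 mL/min/kg to 120 mL/min/kg for this measurement.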

Compound 4, clearance: 61 mL/min/kg
Compound 4: the middle estimate sits 1.0-fold (0.01 log units) below what was measured; the measured number falls inside the stated range.
By their numbers in this assay, from the lowest: compounds 3, 2, 4 and 1 (each within the scatter of the next, the first and the last beyond it).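

In this assay a non-aromatic ring on the amide-type nitrogen can now be read against the aromatic ones, and a 1.1-fold lower number from compound 1 to compound 4 (0.04 log units; within the scatter) puts cyclopentyl level with phenyl on this read-out. The separation at this position therefore belongs to 2,4-difluorophenyl alone: a 2.3-fold higher number from compound 3 to compound 4 (0.35 log units; beyond the scatter) is a modest step of the same class as a 2.5-fold lower number from compound 1 to compound 3 (0.39 log units; beyond the scatter) while a 1.3-fold higher number from compound 2 to compound 4 (0.12 log units; within the scatter) stays inside the noise, as does the step from compound 2 to compound 3 printed earlier. Among these four groups, compound 3 thus stands clear of compound 1 and compound 4 but not of compound 2, and no wider trend across the four follows from that.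

Still open, from the compounds shown here alone, is whether the lower number of compound 3 needs fluorine on an aromatic ring, or whether a difluorocyclopentyl group on the same nitrogen would give a similar number, and whether a ring carrying an amine or an ether oxygen, such as a piperidine or a tetrahydropyran, would sit with compound 3 or with compound 4. No supporting data bear on why 2,4-difluorophenyl stands apart from cyclopentyl and phenyl on this read-out.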